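A few compounds are considered here, and "the series" means these few. Any claim that something is new, unique, unknown or untested is made for them only; others in the source may bear on it.

Compound 1 `CC(C)NC(=O)c1cc(Oc2cccc(NC(=S)Nc3ccc(Cl)cc3)c2)ccn1` gives 87500 nM in a functional assay on MDA-MB-231 cells (Homo sapiens) for cytotoxicity, read by MTT assay, with a stated time of 48 h; a lower number here means a stronger inhibitor, a higher number a weaker inhibitor.
Compound 2 `O=C(NCc1ccccc1)c1cc(Oc2cccc(NC(=S)Nc3ccc(Cl)cc3)c2)ccn1` shows only a limit of the assay, > 100000 nM.
Compound 3 `O=C(c1cc(Oc2cccc(NC(=S)Nc3cccc(C(F)(F)F)c3)c2)ccn1)N1CCCC1` gives 35400 nM.

Of the two plain numbers, compound 1 holds the higher one, and the gap down to compound 3 lies beyond the usual scatter. Compound 4 `CC(C)NC(=O)c1cc(Oc2cccc(NC(=S)Nc3ccc(OC(F)(F)F)cc3)c2)ccn1` differs from compound 1 by trifluoromethoxy in place of chloro on an aromatic carbon. Among the compounds with values here, the only measured step, an at least 1.1-fold higher number from compound 1 to compound 2 (0.05 log units; that floor lies within the scatter), alters the group on the amide-type nitrogen, not the aromatic carbon changed here, so it offers no direct guide, and no measured pair covers this position. Without such a guide, no shift beyond the scatter is expected. Compound 4 is therefore estimated at 80000 nM, within 30000 nM to 200000 nM. That estimate means an expected step of a 1.1-fold lower number from compound 1 to compound 4 (0.04 log units; within the scatter).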

Compound 4, half-maximal inhibitory concentration: > 100000 nM
Compound 4: no number, only a limit; the forecaster's own chance of this, stated with the estimate: 30%; middle value at least 1.2-fold (0.09 log units) from the limit.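

Trifluoromethoxy in place of chloro, the first change shown on this aromatic carbon, gives an at least 1.1-fold higher number from compound 1 to compound 4 (0.05 log units; that floor lies within the scatter). Compound 4 has a limit rather than a number, so this step is only a floor, and the swap brings no sign of a stronger inhibitor in this assay. The true size of the step cannot be read, because the reading stops at a limit: the limit of > 100000 nM in this assay, at which 2 of the 4 values shown sit.

The compounds shown leave open whether another group on this aromatic carbon, such as an amine or a carboxylic acid, would give a lower number. They also leave open how trifluoromethoxy behaves with benzyl on the amide-type nitrogen.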